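A few compounds are considered here, and "the series" means these few. Any claim that something is new, unique, unknown or untested is made for them only; others in the source may bear on it.

Working notes on the series.

Three compounds of this set have been run in a functional assay on HepG2 cells (Homo sapiens) for cytotoxicity, read by MTT assay, with a stated time of 48 h; a higher number here means a weaker inhibitor, a lower number a stronger inhibitor. Compound 1, `CCC(=O)N1N=C(C)CC1c1cc(Br)cc(Br)c1O`, gives 41400 nM. Compound 2, `CC1=NN(C(=O)CN2CCC(c3ccccc3)CC2)C(c2ccccc2O)C1`, gives 23300 nM. Compound 3, `CNCC(=O)N1N=C(c2cc3ccccc3oc2=O)CC1c1ccccc1`, gives 24000 nM. Compound 3 stands second highest of the three numbers; its nearest neighbour is compound 2 and its furthest is compound 1, and both gaps lie within the usual scatter, so the three numbers cannot be told apart on these data. Every value sits in the weak range for this assay.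

Compound 4, `O=C(CN1CCC(O)CC1)N1N=C(c2cc3ccccc3oc2=O)CC1c1ccccc1`, has not yet been measured. Compared with compound 3 it shows the following difference: 4-hydroxypiperidin-1-yl in place of methylamino on a saturated chain carbon bound to a carbonyl carbon. For the measured compounds named here, no pair of measured compounds differing in one place is available, so no measured step guides this change. Compound 2 carries a substituted piperidin-1-yl on the same kind of chain carbon and gives 23300 nM, a number that does not separate from compound 3 beyond the scatter. On that basis the expected step from compound 3 to compound 4 in this assay, a 1.0-fold higher number from compound 3 to compound 4 (0.02 log units; within the scatter), is none beyond the scatter, in either direction. Compound 4 is therefore estimated at 25000 nM, with a range from 10000 nM to 60000 nM.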

Compound 4, half-maximal inhibitory concentration: "not active" (no number reported)
Compound 4 has no reported number here, so the estimate cannot be set against anything.
By their numbers in this assay, from the lowest: compounds 2, 3 and 1 (each within the scatter of the next).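

For the compounds shown here, compound 4 is reported as not active in this assay with no number given, so no step from compound 3 to compound 4 can be read. No measured evidence bears on this result. The compounds shown leave open how 4-hydroxypiperidin-1-yl in place of methylamino on a saturated chain carbon bound to a carbonyl carbon shifts the number in this assay on this core.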